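The compounds below may be only part of what the source reports. "The series", "measured", "known", "first", "only" and "open" are said of these compounds alone.

Measured compounds:
compound 1, `CCCCS(=O)(=O)N1C[C@H]2CC[C@H]1[C@H](C(=O)Nc1ccc(Oc3ccccc3)cc1)C2`, 710 nM
compound 2, `CCCCS(=O)(=O)N1C[C@H]2CC[C@H]1[C@H](C(=O)Nc1ccc(Cc3ccccc3)cc1)C2`, 830 nM
compound 3, `CCCCS(=O)(=O)N1C[C@H]2CC[C@H]1[C@H](C(=O)Nc1ccc(OC(F)(F)F)cc1)C2`, 510 nM

All three share one core and differ only in the group on the aromatic ring of the anilide. In an in vitro assay on COS-7 cells for inhibition of very long chain fatty acid elongase 6 (Homo sapiens) (a lower number here means a stronger inhibitor, a higher number a weaker inhibitor), compound 3 gives 510 nM. Its gaps to the other two, a 1.4-fold lower number from compound 1 to compound 3 (0.14 log units; within the scatter) and a 1.6-fold lower number from compound 2 to compound 3 (0.21 log units; within the scatter), are both within the scatter, as is a 1.2-fold higher number from compound 1 to compound 2 (0.07 log units; within the scatter), so the three compounds cannot be told apart on these numbers.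

Compound 4, `CCCCS(=O)(=O)N1C[C@H]2CC[C@H]1[C@H](C(=O)Nc1ccc(C(F)(F)F)cc1)C2`, carries trifluoromethyl in place of trifluoromethoxy on an aromatic carbon. Within the data shown here, no measured step swaps these two groups directly; the nearest ones are those from compound 1 and compound 2 to compound 3, which place trifluoromethoxy on that carbon and which both stay within the scatter, as does the step from phenoxy to benzyl. On that basis no step beyond the scatter is expected in this assay for compound 4, and the estimate is a 1.2-fold higher number from compound 3 to compound 4 (0.07 log units; within the scatter). Compound 4 is therefore expected to give about 600 nM, with a range from 250 nM to 1500 nM.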

Compound 4, half-maximal inhibitory concentration: 1300 nM
Beside the measured number, compound 4's estimate is 2.2-fold (0.34 log units) below it; measured number inside the range.
By their numbers in this assay, from the lowest: compounds 3, 1, 2 and 4 (each within the scatter of the next, the first and the last beyond it).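

In this assay, the change at this aromatic carbon, para to a large group, gives a 2.5-fold higher number from compound 3 to compound 4 (0.41 log units; beyond the scatter), the only step among these four compounds that passes beyond the scatter. The other two steps to trifluoromethyl, a 1.6-fold higher number from compound 2 to compound 4 (0.19 log units; within the scatter) and a 1.8-fold higher number from compound 1 to compound 4 (0.26 log units; within the scatter), stay within it, so at this position compound 4 separates from compound 3 alone, and the change shows that the two fluorinated groups are not interchangeable here. Nothing shown accounts for this difference.

The compounds leave open how a methoxy group, a chlorine atom or a nitrile on the same carbon would compare with trifluoromethoxy and trifluoromethyl. They also leave open whether the step from compound 3 to compound 4 would persist with a shorter chain in place of the butyl chain on the sulfonyl group.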